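Replacing the 4-fluorophenyl amide group in compound 1

The source may hold more compounds than are shown below. What is called first, only, known or untested is meant among the compounds shown, and "the series" means these compounds.

In a toxicity assay on THP-1 cells (Homo sapiens) for inhibition (on this read-out lower numbers stand for higher toxicity in this test and higher numbers for lower toxicity in this test), compound 1 (`Cn1c(-c2ccccc2)cnc1NC(=O)c1ccc(F)cc1`) gives > 100000 nM as a limit of the assay and not a number. Compound 3 (`Cn1c(-c2ccccc2Cl)cnc1NC(=O)c1ccc(F)cc1`) gives > 50000 nM as another limit of this assay and not a number. Going by the values given here, compound 2 (`Cn1c(-c2ccc(Br)cc2)cnc1NC(=O)c1ccc(F)cc1`) gives 46000 nM as the one measured number so far.

The change to compound 4 (`Cc1cccc(C(=O)Nc2ncc(-c3ccccc3)n2C)c1`) is 3-methylphenyl in place of 4-fluorophenyl on a carbonyl carbon and the core of compound 1 stays the same. Among the compounds with values here, no measured step changes the group on the carbonyl carbon, so the available steps are only a loose guide. Bromo in place of hydrogen on an aromatic carbon gives an at least 2.1-fold lower number from compound 1 to compound 2 (0.33 log units; beyond the scatter) and this step lies beyond the scatter. A chloro group as the new substituent gives a step that the two limits leave unreadable from compound 1 to compound 3 and its size cannot be read. A modest move towards lower numbers is therefore expected at most, and the estimated step is an at least 1.4-fold lower number from compound 1 to compound 4 (0.15 log units; that floor lies within the scatter) in this reading. For compound 4 the estimated value is 70000 nM with an expected range from 30000 nM to 150000 nM and a report of only a limit is also quite possible.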

Compound 4, half-maximal cytotoxic concentration: > 50000 nM
Compound 4 gave a limit, no number (the forecaster's own chance of this, stated with the estimate: 55%); the middle value does not contradict the limit.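

In this assay compound 1 and compound 4 both give limits of the assay and not numbers, so the step between them cannot be read. The compounds shown leave open whether 3-methylphenyl in place of 4-fluorophenyl on a carbonyl carbon shifts the read-out at all.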